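Swapping the Aryl Amide Group on a Shared Core

A few compounds are considered here, and "the series" means these few. Any claim that something is new, unique, unknown or untested is made for them only; others in the source may bear on it.

Compound 1 `O=C(Nc1ccc(Cl)c(-c2nnc3c(Cl)cccn23)c1)c1cccc(Cl)c1` gives 71900 nM in a functional assay on MCF7 cells (Homo sapiens) for antiproliferative activity, read by MTT assay, with a stated time of 72 h; a lower number here means a stronger inhibitor, a higher number a weaker inhibitor. Compound 2 `O=C(Nc1ccc(Cl)c(-c2nnc3c(Cl)cccn23)c1)c1c(F)cccc1Cl` gives > 100000 nM in this assay, which is a limit of the assay and not a number. Compound 3 `O=C(Nc1ccc(Cl)c(-c2nnc3c(Cl)cccn23)c1)c1ccc(Cl)cc1Cl` gives 78200 nM in this assay.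

All three compounds share one core and differ only in the aryl group attached to the carbonyl carbon of the amide. Compound 3 has the highest of the two numbers, but its nearest neighbour, compound 1, sits within the scatter a 1.1-fold higher number from compound 1 to compound 3 (0.04 log units; within the scatter). The steps to compound 2 are bounded by the limit of > 100000 nM in this assay, at which 1 of the 3 values shown sits, and are also small: an at least 1.3-fold higher number from compound 1 to compound 2 (0.14 log units; that floor lies within the scatter) and an at least 1.2-fold lower number from compound 2 to compound 3 (0.10 log units; that floor lies within the scatter).

Compound 4 `CS(=O)(=O)c1cccc(C(=O)Nc2ccc(Cl)c(-c3nnc4c(Cl)cccn34)c2)c1` has not yet been measured. It changes the same position: 3-(methylsulfonyl)phenyl in place of 2,4-dichlorophenyl on a carbonyl carbon. Every measured change at this position left the number within the scatter, so no step beyond the scatter is expected for compound 4 either. The expected step is a 1.0-fold higher number from compound 3 to compound 4 (0.01 log units; within the scatter). Compound 4 is therefore estimated at 80000 nM, between 30000 nM and 200000 nM.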

Compound 4, half-maximal inhibitory concentration: 88900 nM
Compound 4: middle estimate off by 1.1-fold (0.05 log units), on the low side; the measured number falls inside the stated range.
By their numbers in this assay, from the lowest: compounds 1, 3 and 4 (each within the scatter of the next). At a limit, above all of these: compound 2.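

Compound 4 puts a 3-(methylsulfonyl)phenyl group, with 2 hydrogen-bond acceptors, where 2,4-dichlorophenyl has 0, yet the number in this assay stays within the scatter (a 1.1-fold higher number from compound 3 to compound 4 (0.06 log units; within the scatter)). Methylsulfonyl in place of chloro on an aromatic carbon also leaves the number within the scatter (a 1.2-fold higher number from compound 1 to compound 4 (0.09 log units; within the scatter)), so among compounds 1, 3 and 4, a change to a group without any halogen moves nothing beyond the scatter. Compound 2 has a limit and not a number, so its step (an at least 1.1-fold lower number from compound 2 to compound 4 (0.05 log units; that floor lies within the scatter)) is only a floor: the limit of > 100000 nM in this assay, at which 1 of the 4 values shown sits.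

All the groups shown at this position are substituted phenyl rings, so what an amine, a carboxylic acid or a longer chain would do here stays open. Why the numbers stay so close together also stays open, as does whether any group here can move the number beyond the scatter.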